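The compounds below may be only part of what the source reports. "The series", "measured", "known", "first", "only" and "open" are said of these compounds alone.

Working notes on the series. All compounds share one core and differ only in the aromatic group carried on a nitrogen on an aromatic ring. Compound 1 `Cn1c(=O)c(S(=O)(=O)c2ccc(F)cc2F)cc2cnc(Nc3cccc4[nH]ccc34)nc21` gives 1500 nM in a functional assay on K562 cells (Homo sapiens) for inhibition, read by trypan blue exclusion, with a stated time of 72 h; a lower number here means a stronger inhibitor, a higher number a weaker inhibitor. Compound 2 `Cn1c(=O)c(S(=O)(=O)c2ccc(F)cc2F)cc2cnc(Nc3ccc4[nH]c(C(=O)O)cc4c3)nc21` gives 10000 nM in this assay, and compound 3 `Cn1c(=O)c(S(=O)(=O)c2ccc(F)cc2F)cc2cnc(Nc3ccc4cccc(O)c4n3)nc21` gives 5000 nM. Among these three numbers compound 3 stands second highest: its nearest step is a 2.0-fold lower number from compound 2 to compound 3 (0.30 log units; within the scatter), and its furthest step is a 3.3-fold higher number from compound 1 to compound 3 (0.52 log units; beyond the scatter). Going by the values given here, the remaining step, a 6.7-fold higher number from compound 1 to compound 2 (0.82 log units; beyond the scatter), marks the 2-carboxy-1H-indol-5-yl compound as the weakest of the three measured so far.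

Compound 4 `Cc1cc2cc(Nc3ncc4cc(S(=O)(=O)c5ccc(F)cc5F)c(=O)n(C)c4n3)ccc2[nH]1` is not yet measured. It differs from compound 3 as follows: 2-methyl-1H-indol-5-yl in place of 8-hydroxyquinolin-2-yl on a nitrogen on an aromatic ring. Among the compounds with values here, the steps that bear on this change are the three swaps of the same group already seen, a 6.7-fold higher number from compound 1 to compound 2 (0.82 log units; beyond the scatter), a 3.3-fold higher number from compound 1 to compound 3 (0.52 log units; beyond the scatter) and a 2.0-fold lower number from compound 2 to compound 3 (0.30 log units; within the scatter), all of modest size. Compound 2 is the nearest comparator, sharing the indol-5-yl attachment but carrying a carboxy group where compound 4 carries a methyl group; compound 1 shows what a plain indole reaches. A small move toward the lower numbers of the series is therefore expected, not clearly beyond the scatter. The step expected in this assay is a 2.0-fold lower number from compound 3 to compound 4 (0.30 log units; within the scatter). Compound 4 is estimated at 2500 nM, with a range from 800 nM to 8000 nM.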

Compound 4, half-maximal inhibitory concentration: 750 nM
For compound 4 the middle estimate is 3.3-fold (0.52 log units) above the measured one; the whole stated range lies above it.
By their numbers in this assay, from the lowest: compounds 4 and 1 (each within the scatter of the next); then compounds 3 and 2 (each within the scatter of the next).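

In this assay, going by these compounds alone, methyl in place of carboxy on an aromatic carbon gives a 13-fold lower number from compound 2 to compound 4 (1.12 log units; beyond the scatter), the only large step, so the substituent on the indol-5-yl group matters far more than the earlier swaps of whole aromatic groups suggested. The 2-methyl-1H-indol-5-yl group also separates clearly from the 8-hydroxyquinolin-2-yl group, with a 6.7-fold lower number from compound 3 to compound 4 (0.82 log units; beyond the scatter) beyond the scatter, while a 2.0-fold lower number from compound 1 to compound 4 (0.30 log units; within the scatter) stays within it, so an indol-5-yl attachment can match the plain 1H-indol-4-yl group once the carboxy group is gone. No measurement available here accounts for these steps.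

The compounds shown include no indol-5-yl group without a substituent on that aromatic carbon, so it remains open whether the methyl group contributes to the low number of compound 4 or whether the carboxy group of compound 2 alone raises the number. Also open, on these data alone, is how an amine, a methyl ester or a longer alkyl chain on the same aromatic carbon would read in this assay and whether any of these would move clear of the scatter around compound 4.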